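The source may report more compounds than this note shows. Statements on the series, on what has been measured and on what is new or still open speak of the compounds shown alone.

Compound 1 `C=C(C)CCOC(=O)C[C@@H]1C(C(=O)OC)=CO[C@@H](O[C@@H]2O[C@H](COC(C)=O)[C@@H](OC(C)=O)[C@H](OC(C)=O)[C@H]2OC(C)=O)/C1=C/C` carries the 3-methylbut-3-en-1-yl ester on the shared core with an acetylated sugar. In a functional assay on SK-BR-3 cells (Homo sapiens) for antiproliferative activity, read by MTT assay, with a stated time of 72 h (a higher number here means a weaker inhibitor, a lower number a stronger inhibitor), compound 1 gives > 15000 nM, which is a limit of the assay rather than a number. Compound 2 `C#CCOC(=O)C[C@@H]1C(C(=O)OC)=CO[C@@H](O[C@@H]2O[C@H](CO)[C@@H](O)[C@H](O)[C@H]2O)/C1=C/C` has a free sugar and a different ester; in this assay compound 2 gives > 15000 nM, again a limit. Compound 3 `C/C=C1/[C@H](O[C@@H]2O[C@H](CO)[C@@H](O)[C@H](O)[C@H]2O)OC=C(C(=O)OC)[C@H]1CC(=O)OCCc1ccc([N+](=O)[O-])cc1` bears the 4-nitrobenzyl ester; in this assay compound 3 gives > 20000 nM, also a limit. Within the data shown here, the one single-point comparison among the measured compounds, a step that the two limits leave unreadable from compound 2 to compound 3, cannot be read in size, since both of its ends rest at limits (the limit of > 15000 nM in this assay, at which 2 of the 3 values shown sit, (the limit of > 20000 nM in this assay, at which 1 of the 3 values shown sits)). Compound 1 therefore stands only at a limit, and the two other values are limits as well. Compound 4 `C/C=C1/[C@H](O[C@@H]2O[C@H](COC(C)=O)[C@@H](OC(C)=O)[C@H](OC(C)=O)[C@H]2OC(C)=O)OC=C(C(=O)OC)[C@H]1CC(=O)OCCCC` differs from compound 1 by ethyl in place of 1-methylethenyl on a saturated chain carbon, two bonds along the chain from an oxygen next to a carbonyl group. Among the measured compounds shown here, no measured step bears on this change with a readable size, so the step that the limit leaves unreadable from compound 1 to compound 4 is expected to be none beyond the scatter, with compound 4 expected to remain at the limit. Compound 4 is estimated at 20000 nM, with a range from 8000 nM to 60000 nM.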

Compound 4, half-maximal inhibitory concentration: > 15000 nM
Compound 4 gave a limit, no number (the forecaster's own chance of this, stated with the estimate: 85%); the middle value is on the limit's open side.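

In this assay, among these compounds, compound 4 gives > 15000 nM, a limit of the assay, so no step from compound 1 to compound 4 can be read. The compounds shown leave open what effect, if any, a change of ester or of the sugar's acetyl groups has in this assay, with every value shown a limit.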